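The source may report more compounds than this note shows. Statements on the series, on what has been measured and on what is new or still open speak of the compounds shown alone.

In a functional assay on A549 cells (Homo sapiens) for antiproliferative activity, read by MTT assay, with a stated time of 72 h (on this read-out higher numbers stand for weaker inhibition and lower numbers for stronger inhibition), compound 1 `COc1cc2ncnc(Nc3ccc(OCc4cccc(F)c4)c(Cl)c3)c2cc1OCCCN1CCNCCNCCNCC1` gives 3400 nM, while compound 2 `COc1cc2ncnc(Nc3cccc(Cl)c3)c2cc1OCCCN1CCNCCNCCNCC1` gives 27100 nM, the higher of the two numbers and so the weaker inhibition. Compound 3 `CCc1cc(Br)ccc1Nc1ncnc2cc(OC)c(OCCCN3CCNCCNCCNCC3)cc12` has not yet been measured. It differs from compound 2 only in the aromatic group on the nitrogen: 4-bromo-2-ethylphenyl in place of 3-chlorophenyl on a nitrogen on an aromatic ring. Here, 4-bromo-2-ethylphenyl takes the place of 3-chlorophenyl.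

Going by the values given here, only one measured step bears on this change: an 8.0-fold higher number from compound 1 to compound 2 (0.90 log units; beyond the scatter). That step swaps (3-fluorobenzyl)oxy for hydrogen on this same aromatic group, so it shows that changes there can move the number. However, it involves a different substituent and is only a loose guide. A modest step towards a lower number in this assay therefore seems likelier than none, though with little certainty. The expected change is a 2.3-fold lower number from compound 2 to compound 3 (0.35 log units; beyond the scatter). For compound 3 the estimated value is 12000 nM, with an expected range of 4000 nM to 35000 nM.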

Compound 3, half-maximal inhibitory concentration: > 50000 nM
Compound 3: a limit, no number; the forecaster's own chance of this, stated with the estimate: 10%; at least 4.1-fold (0.61 log units) between middle value and limit.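

Compound 3 has no number, only a limit of the assay: the limit of > 50000 nM in this assay, at which 1 of the 3 values shown sits. Replacing 3-chlorophenyl with 4-bromo-2-ethylphenyl gives an at least 1.8-fold higher number from compound 2 to compound 3 (0.26 log units; that floor lies within the scatter), so this change cannot be called a loss beyond the usual scatter, but it gives no sign of stronger inhibition either. Going by these compounds alone, the earlier step, an 8.0-fold higher number from compound 1 to compound 2 (0.90 log units; beyond the scatter), showed only that this aromatic group can affect the result; the new step adds that a larger group here does not necessarily give a lower number.

The compounds shown do not separate the bromine from the ethyl group, so a ring carrying only one of them would be needed to tell which matters. On these data alone, it also remains open how a smaller group on this ring, such as a fluorine or an amine, would behave.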